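The compounds below may be only part of what the source reports. "The series", "measured", "known", "first", "only" and "open" are said of these compounds alone.

Two members of the series have been run in a functional assay on BGC-823 cells (Homo sapiens) for cytotoxicity, read by MTT assay; on this read-out higher numbers stand for weaker inhibition and lower numbers for stronger inhibition. Compound 1 `Cc1nc(Nc2cccc(Cl)c2)sc1C(=O)/C=C/c1ccccc1` carries a 3-chlorophenylamino group on the shared core and an unsubstituted phenyl on the enone. In this assay compound 1 gives > 25000 nM, which is a limit of the assay and not a number. Compound 2 `Cc1ccc(Nc2nc(C)c(C(=O)/C=C/c3ccc(Cl)cc3)s2)cc1` carries a 4-methylphenylamino group and a 4-chlorophenyl on the enone. In this assay compound 2 gives > 25000 nM, likewise a limit and not a number. Compound 2 therefore stands where both values shown sit, namely at the limit of > 25000 nM in this assay, at which 2 of the 2 values shown sit. Compound 3 `Cc1nc(Nc2cccc(Cl)c2)sc1C(=O)/C=C/c1ccc(Cl)cc1` differs from compound 2 in one place: 3-chlorophenyl in place of 4-methylphenyl on a nitrogen on an aromatic ring. Within the data shown here, no measured pair reports this exchange. Since compound 1 already holds the 3-chlorophenylamino group and gives > 25000 nM, the step expected from compound 2 to compound 3 is a step that the limit leaves unreadable from compound 2 to compound 3, none beyond the scatter. Compound 3 is estimated at 30000 nM, with a range from 10000 nM to 100000 nM, most likely reported again as a limit.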

Compound 3, half-maximal inhibitory concentration: > 25000 nM
Compound 3 gave a limit, no number; the forecaster's own chance of this, stated with the estimate: 80%; the middle value lies beyond the limit too.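

The steps to compound 3 from compound 2 and from compound 1 cannot be read, because all three compounds sit at one limit in this assay: the limit of > 25000 nM in this assay, at which 3 of the 3 values shown sit. The compounds shown leave open whether either exchange, 3-chlorophenyl for 4-methylphenyl or chloro for hydrogen, changes cytotoxicity at all.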